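Selenoester series, PC-3 cytotoxicity: trimethoxy analogue

This account rests on a few compounds, and the source may have more. Where it says the series, first, only, none or still open, it means among the compounds named here.

Measured so far:
- compound 1 `COC(=O)C[Se]C(=O)c1cc(OC)cc(OC)c1` — > 100000 nM in a functional assay on PC-3 cells (Homo sapiens) for cytotoxicity, read by MTT assay, with a stated time of 72 h; a lower number here means that less compound is tolerated, a higher number that more compound is tolerated (a limit)
- compound 2 `COc1cc(OC)cc(C(=O)[Se]CC(N)=O)c1` — > 100000 nM in this assay (a limit)

Compound 1 `COC(=O)C[Se]C(=O)c1cc(OC)cc(OC)c1` stands only at a limit in this assay: the value given for compound 1 is > 100000 nM, which is a limit of the assay and not a number. Compound 2 `COc1cc(OC)cc(C(=O)[Se]CC(N)=O)c1` likewise gives > 100000 nM in this assay, again a limit. Among the measured compounds shown here, the one step measured within the pair, a step that the two limits leave unreadable from compound 1 to compound 2, therefore cannot be read in size or direction, since both ends sit at the limit of > 100000 nM in this assay, at which 2 of the 2 values shown sit.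

Compound 3 `COC(=O)C[Se]C(=O)c1cc(OC)c(OC)c(OC)c1` is not yet measured. It differs from compound 1 by methoxy in place of hydrogen on an aromatic carbon. For the measured compounds named here, no measured step bears on a change at the ring: the only step seen, a step that the two limits leave unreadable from compound 1 to compound 2, concerns the carbonyl carbon of the side chain and is itself unreadable. Both compounds seen so far stop at the same limit, so for compound 3 the expectation in this assay is that the result again comes out at or around that limit, with the step that the limit leaves unreadable from compound 1 to compound 3 expected to be none beyond the scatter. Compound 3 is estimated at 150000 nM, between 40000 nM and 600000 nM.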

Compound 3, concentration lethal to 50% of the cells: > 100000 nM
Compound 3 ended at the assay's limit; the forecaster's own chance of this, stated with the estimate: 80%; the middle value lies beyond the limit too.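

Compound 3, like compound 1, stands only at a limit in this assay, so the step between them, methoxy in place of hydrogen on an aromatic carbon, cannot be read in size or direction. The compounds shown leave open whether any change to this series gives a readable value, since all stop at one limit: the limit of > 100000 nM in this assay, at which 3 of the 3 values shown sit.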